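The compounds below may be only part of what the source reports. "The series", "measured", "known", "first", "only" and "open" are said of these compounds alone.

Compound 3, `CN(C)CCCNc1nc(N)nc2cc(-c3ccc(C(F)(F)F)cc3)sc12`, has been measured in a physicochemical assay for solubility, in phosphate buffer, at pH 6.5 (a higher number here means a more soluble compound, a lower number a less soluble compound), and gives 148 ug/mL. Two other compounds share this assay. Compound 1, `CNc1nc(NCCN2CCNCC2)c2sc(-c3ccc(C(F)(F)F)cc3)cc2n1`, gives 115 ug/mL in this assay, and its value and that of compound 3 lie within the usual scatter of each other, so no order between them can be read. Compound 2, `CNc1nc(NC(C)(C)C)c2sc(-c3ccc(C(F)(F)F)cc3)cc2n1`, returns only a limit in this assay, < 1.6 ug/mL. That figure is the limit of < 1.6 ug/mL in this assay, at which 1 of the 3 values shown sits. Among the measured compounds shown here, the single step between measured compounds that differ in one place is an at least 71-fold lower number from compound 1 to compound 2 (1.85 log units; beyond the scatter), a large movement.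

Compound 4, `CN(C)CCCNc1nc(NCc2ccccc2)nc2cc(-c3ccc(C(F)(F)F)cc3)sc12`, is not yet measured. It differs from compound 3 in one place: benzyl in place of hydrogen on a nitrogen on an aromatic ring. For the measured compounds named here, no measured step matches this change exactly, since the step from compound 1 to compound 2 exchanges one substituent for another rather than replacing hydrogen with a group; it does show, however, that a change on a ring nitrogen can move the read-out by a large amount. Compound 4 is therefore expected to sit lower than compound 3, with an estimated step of a 7.4-fold lower number from compound 3 to compound 4 (0.87 log units; beyond the scatter). For compound 4 the estimate in this assay is 20 ug/mL, with a range from 4 ug/mL to 80 ug/mL.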

Compound 4, solubility: < 5 ug/mL
Compound 4: a limit, no number (the forecaster's own chance of this, stated with the estimate: 10%); middle value at least 4.0-fold (0.60 log units) from the limit.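

Set on the amino nitrogen of compound 3, benzyl gives an at least 29-fold lower number from compound 3 to compound 4 (1.47 log units; beyond the scatter) in this assay, so this position, with hydrogen replaced by a group of carbon only, can by itself produce a large step. The earlier step, an at least 71-fold lower number from compound 1 to compound 2 (1.85 log units; beyond the scatter), changed the substituent on a different nitrogen and removed the piperazine-bearing chain, whereas compound 4 keeps the side chain of compound 3, so this result shows that retaining that chain does not protect the read-out from a large fall. Compound 4 returns only a limit, and compound 2 is the other compound in this set to do so: the limit of < 5 ug/mL in this assay, at which 1 of the 4 values shown sits.

Going by these compounds, a single substituent cannot separate the contribution of the benzyl ring from that of the added carbon count, so it remains open whether a small ethyl group or a longer phenethyl chain on this nitrogen would give a similar step. On these data alone, it also remains open whether a benzyl group carrying a carboxylic acid or an amine would keep the number nearer that of compound 3.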